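Methoxy added to the terminal phenyl of compound 3

This account rests on a few compounds, and the source may have more. Where it says the series, first, only, none or still open, it means among the compounds named here.

The series shares an amide-linked core carrying a biaryl acid, followed in a functional assay on PC-3 cells (Homo sapiens) for cytotoxicity, read by MTT assay, with a stated time of 72 h; on this read-out lower numbers stand for stronger inhibition and higher numbers for weaker inhibition. Compound 3 `O=C(Nc1ccc(Oc2ccnc3[nH]ccc23)c(F)c1)c1ccc(-c2ccccc2)cn1` gives 760 nM and stands lowest of the two numbers present; the nearest is compound 2 `Cc1cccc(-c2ccnc(C(=O)Nc3ccc(Oc4ccnc5[nH]ccc45)cc3)c2)c1`, which gives 5470 nM, a gap beyond the scatter. Compound 1 `CCc1ccc(-c2ccc(C(=O)Nc3ccc(Oc4ccnc5[nH]ccc45)cc3)nc2)cc1` reports only a limit, > 10000 nM. That limit is the one recorded as the limit of > 10000 nM in this assay, at which 1 of the 3 values shown sits. Among the compounds with values here, no pair of measured compounds differs in a single place, so no step size is measured in this set.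

Compound 4 `COc1ccc(-c2ccc(C(=O)Nc3ccc(Oc4ccnc5[nH]ccc45)c(F)c3)nc2)cc1` differs from compound 3 by methoxy in place of hydrogen on an aromatic carbon. Compound 1 carries an ethyl group on its terminal ring and lacks the fluorine of compound 3, and its result is only a limit; compound 4 keeps the fluorine and adds a methoxy instead, so a loss is expected but a smaller one than that seen for compound 1. In this assay the estimated step is a 2.9-fold higher number from compound 3 to compound 4 (0.46 log units; beyond the scatter), a weakening beyond the scatter. Compound 4 is expected at 2200 nM, with a range of 600 nM to 8000 nM.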

Compound 4, half-maximal inhibitory concentration: 650 nM
Compound 4: middle estimate off by 3.4-fold (0.53 log units), on the high side, within the range that was stated.
By their numbers in this assay, from the lowest: compounds 4 and 3 (each within the scatter of the next); then compound 2. At a limit, above all of these: compound 1.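

In this assay the terminal phenyl accepts a group para to a large group with no readable change in the number: a 1.2-fold lower number from compound 3 to compound 4 (0.07 log units; within the scatter). Within the data shown here, this is the first step between compounds that differ in one place, and it places compound 3 and compound 4 at the same level, so on this read-out the change from phenyl to 4-methoxyphenyl neither gains nor loses anything that can be told from the scatter. No measured property shown here bears on why this step is so small.

A single substituent at a single position leaves open whether the same position would stay as permissive for an amine, a carboxylic acid or a longer chain such as propoxy. Compound 1 differs from compound 4 in more than one place, both in the group on the terminal ring and in the fluorine, so the contributions of these two features remain unseparated in the compounds shown.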